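Carbonyl versus sulfonyl on the ring nitrogen; methyl versus fluoro

The compounds below may be only part of what the source reports. "The series", "measured", "known", "first", "only" and "open" are said of these compounds alone.

Three compounds on a shared core have been run in a functional assay on NCI-H1975 cells (Homo sapiens) for inhibition, read by sulforhodamine B assay, tested at 10 uM; a higher number here means more inhibition at the concentration tested (going by the name of the read-out), a lower number less inhibition. Compound 1 `Cc1ccc(C(=O)N2N=C(c3ccc(N4CCN(C)CC4)cc3)CC2c2ccc(N(C)C)cc2)cc1` gives -0.4%. Compound 2 `CN1CCN(c2ccc(C3=NN(C(=O)c4ccc(F)cc4)C(c4ccc(N(C)C)cc4)C3)cc2)CC1` gives 32.2%. Compound 3 `Cc1ccc(S(=O)(=O)N2N=C(c3ccc(N4CCN(C)CC4)cc3)CC2c2ccc(N(C)C)cc2)cc1` gives 38.1%.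

Two single-point changes set these apart. The first, (fluoro in place of methyl on an aromatic carbon), carries the step of a number 32.6 percentage points higher from compound 1 to compound 2 (beyond the scatter). The second, ((4-methylphenyl)sulfonyl in place of (4-methylphenyl)carbonyl on an amine nitrogen in a ring), carries the step of a number 38.5 percentage points higher from compound 1 to compound 3 (beyond the scatter). Between the two raised compounds the step is a number 5.9 percentage points higher from compound 2 to compound 3 (within the scatter), so compound 2 and compound 3 cannot be ranked against each other on these numbers; only compound 1 stands apart.

Compound 4 `CN1CCN(c2ccc(C3=NN(S(=O)(=O)c4ccc(F)cc4)C(c4ccc(N(C)C)cc4)C3)cc2)CC1` has not been measured. Among the compounds with values here, it is reached from compound 3 by fluoro in place of methyl on an aromatic carbon, the same change as the one made from compound 1 to compound 2, occurring twice in the set; the place is described in the same words in both cases, and the two cores differ as told under ((4-methylphenyl)sulfonyl in place of (4-methylphenyl)carbonyl on an amine nitrogen in a ring). The earlier step was measured from a low starting point; compound 3 already stands near compound 2, so a step of the same size is not taken for granted. A smaller rise is expected, a number 11.9 percentage points higher from compound 3 to compound 4 (beyond the scatter), resting on the size of a number 32.6 percentage points higher from compound 1 to compound 2 (beyond the scatter) and on the closeness of a number 5.9 percentage points higher from compound 2 to compound 3 (within the scatter). Compound 4 is therefore estimated at 50% in this assay, within 30% to 70%.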

Compound 4, a percentage reported as inhibition, at one concentration (the size of the read-out at that concentration, not a potency): 95.7%
Estimate against measurement, compound 4: 45.7 percentage points below; the whole stated range lies below it.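

In this assay fluoro in place of methyl on the aromatic carbon raises the number on both cores, but the two steps are not of one size: the same change on two cores in this assay, a number 32.6 percentage points higher (beyond the scatter) from compound 1 to compound 2 and a number 57.6 percentage points higher (beyond the scatter) from compound 3 to compound 4, 25 percentage points apart, beyond the scatter of two such steps

On the sulfonyl core the change gives a number 57.6 percentage points higher from compound 3 to compound 4 (beyond the scatter), the exchange of carbonyl for sulfonyl with 4-fluorophenyl held constant gives a number 63.5 percentage points higher from compound 2 to compound 4 (beyond the scatter), and the two changes taken together give a number 96.1 percentage points higher from compound 1 to compound 4 (beyond the scatter), so in these compounds the direction of the fluoro change carries from one core to the other while its size does not. Two pairs of compounds, each read at a single concentration, do not show that the change would give a rise on any further core, nor do they explain why the step is larger on the sulfonyl core.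

The compounds shown leave open whether the larger step belongs to fluoro alone or would also appear with chloro or methoxy at the same place on the ring. They also leave open whether the result would hold with a morpholine in place of the 4-methylpiperazine, or with a simple methyl or a longer alkyl chain in place of the aryl group on the sulfonyl.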